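The source may hold more compounds than are shown below. What is called first, only, known or untested is meant among the compounds shown, and "the series" means these compounds.

In a functional assay on Vero cells (Chlorocebus sabaeus) for cytotoxicity, read by MTT assay (on this read-out lower numbers stand for higher toxicity in this test and higher numbers for lower toxicity in this test), compound 3 `Cc1ccc2c(c1)c(=O)c(C(=O)O)cn2COCCO` reaches only a limit, > 500000 nM. Compound 1 `CCOC(=O)c1cn(COCCO)c2ccc(F)cc2c1=O` likewise gives only a limit, > 500000 nM. Compound 2 `CCOC(=O)c1cn(COCCO)c2ccc(Cl)cc2c1=O` gives 1250000 nM. The size of a step that the limit leaves unreadable from compound 1 to compound 2 cannot be read because of the limit of > 500000 nM in this assay, at which 2 of the 3 values shown sit. Compound 4 `O=C(O)c1cn(COCCO)c2ccc(Cl)cc2c1=O` differs from compound 3 by chloro in place of methyl on an aromatic carbon. Within the data shown here, no measured pair swaps methyl for chloro, so the only related step, chloro in place of fluoro, offers no readable size. The chloro compound 2 and the limit of compound 3 both lie at the low-toxicity end. Compound 4 is therefore expected to show no step beyond the scatter, with an estimated step that the limit leaves unreadable from compound 3 to compound 4. The estimate for compound 4 is 1000000 nM, between 300000 nM and 3000000 nM.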

Compound 4, half-maximal cytotoxic concentration: 1400000 nM
Beside the measured number, compound 4's estimate is 1.4-fold (0.15 log units) below it, and the stated range covers the measured number.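

Hydrogen in place of ethyl on an oxygen next to a carbonyl group gives a 1.1-fold higher number from compound 2 to compound 4 (0.05 log units; within the scatter) in this assay. With chloro on the aromatic carbon, the ethyl ester and the carboxylic acid therefore cannot be told apart in this test. Steps that start from a limit cannot be read, so chloro on this aromatic carbon cannot be sized against methyl or fluoro: the limit of > 500000 nM in this assay, at which 2 of the 4 values shown sit.

From the compounds shown here alone, whether an amine or a nitrile on this aromatic carbon would lower the number stays open. So does the effect of an amide in place of the acid.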